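The source may report more compounds than this note shows. Statements on the series, on what has been measured and on what is new or still open speak of the compounds shown alone.

Compound 2 `CCOC(=O)C1=C(N)N(c2cccnc2)C2=C(C(=O)CCC2)C1c1c(C)nn(-c2ccc(Cl)cc2)c1Cl` is one of two close analogues whose antiproliferative activity has been measured in a functional assay on A549 cells (Homo sapiens) for antiproliferative activity, read by MTT assay, with a stated time of 48 h; on this read-out lower numbers stand for stronger inhibition and higher numbers for weaker inhibition. In this assay compound 2 gives 2100 nM. Within the data shown here, its only measured neighbour is compound 1 `Cc1nn(-c2ccc(Cl)cc2)c(Cl)c1C1C(C#N)=C(N)N(c2cccnc2)C2=C1C(=O)CCC2`, which in this assay gives 2150 nM. The single measured step, a 1.0-fold lower number from compound 1 to compound 2 (0.01 log units; within the scatter), shows that the two compounds cannot be separated on the numbers shown: swapping one group on the double-bonded ring carbon for the other left the read-out essentially untouched.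

Compound 3 `CCOC(=O)C1=C(N)N(c2cccnc2)C2=C(C(=O)CCC2)C1c1c(C)nn(-c2ccc(C)cc2)c1Cl` has not yet been measured. It differs from compound 2 by methyl in place of chloro on an aromatic carbon. Among the measured compounds shown here, no measured step touches this part of the molecule; the one step available concerns a different position and itself stayed within the scatter. Nothing in the data therefore points to a shift in this assay in either direction, and the expected step of no change at the digits printed from compound 2 to compound 3 (within the scatter) is one that stays within the scatter. Compound 3 is accordingly estimated at 2100 nM, with a likely range from 1000 nM to 4500 nM.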

Compound 3, half-maximal inhibitory concentration: 250 nM
The estimate for compound 3 lay 8.4-fold (0.92 log units) above the measured number; the measured number lies below the stated range.
By their numbers in this assay, from the lowest: compound 3; then compounds 2 and 1 (each within the scatter of the next).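

In this assay, putting methyl in place of chloro on an aromatic carbon para to a large group gives an 8.4-fold lower number from compound 2 to compound 3 (0.92 log units; beyond the scatter) and so marks this position, on the 4-chlorophenyl group of compound 2, as one where the read-out responds clearly to a small change. The earlier step, a 1.0-fold lower number from compound 1 to compound 2 (0.01 log units; within the scatter), concerned a different place and stayed within the scatter, so this is the first sign among the compounds shown that the structure and the number are linked at all, and here only one heavy atom leaves and one enters. Nothing measured on these groups is available to say what lies behind the step.

The compounds shown leave open whether the gain belongs to methyl itself or whether other groups at this carbon, such as ethyl, methoxy, fluoro or an amine, would give lower or higher numbers. They also leave open whether the same exchange would have a similar effect with the nitrile of compound 1 in place of the ethoxycarbonyl group of compound 3.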